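The source may hold more compounds than are shown below. What is called first, only, known or untested is meant among the compounds shown, and "the series" means these compounds.

Within the data shown here, in a functional assay on MCF7 cells (Homo sapiens) for antiproliferative activity, read by MTT assay, with a stated time of 72 h (on this read-out lower numbers stand for stronger inhibition and higher numbers for weaker inhibition), only two compounds have numbers so far. Compound 1 (`CCNC(=O)c1cc(Oc2ccc(NC(=O)c3nn(-c4ccccc4OC(F)(F)F)c(=O)cc3C)cc2)ccn1`) gives 15500 nM, and compound 2 (`CCCNC(=O)c1cc(Oc2ccc(NC(=O)c3nn(-c4ccc(C)cc4)c(=O)cc3C)cc2F)ccn1`) gives 34600 nM. Compound 2 therefore holds the higher number of the two, which means the weaker inhibition, and the gap between them is larger than the usual scatter of repeated measurements.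

Compound 3 (`CCCNC(=O)c1cc(Oc2ccc(NC(=O)c3nn(-c4cccc(C(F)(F)F)c4)c(=O)cc3C)cc2F)ccn1`) keeps the structure of compound 2 except for one group: 3-(trifluoromethyl)phenyl in place of 4-methylphenyl on an aromatic nitrogen. Among the measured compounds shown here, no measured pair differs only at this place, so there is no direct guide to the effect of the swap. The only hint is weak: compound 1 also carries fluorine on the group at that nitrogen and gives 15500 nM, but it differs from compound 2 elsewhere as well.

A small step toward a lower number is therefore expected in this assay, a 1.6-fold lower number from compound 2 to compound 3 (0.20 log units; within the scatter), and it may not clear the scatter. For compound 3 the estimated value is 22000 nM, with an expected range of 9000 nM to 50000 nM.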

Compound 3, half-maximal inhibitory concentration: 30000 nM
Compound 3: middle estimate off by 1.4-fold (0.13 log units), on the low side, and the stated range covers the measured number.
By their numbers in this assay, from the lowest: compounds 1, 3 and 2 (each within the scatter of the next, the first and the last beyond it).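

In this assay, among these compounds, the exchange of 4-methylphenyl for 3-(trifluoromethyl)phenyl on the aromatic nitrogen gives a 1.2-fold lower number from compound 2 to compound 3 (0.06 log units; within the scatter), which is the first direct reading at this position, and on it the two groups cannot be told apart. The entering group has more heavy atoms and carries fluorine, while the leaving group has none, yet with the rest of the structure held constant, these differences leave no readable mark on the number in this assay. Nothing measured here explains this result, so it stands only as an observation.

As far as these compounds go, one pair cannot show whether this position is generally insensitive, so it remains open whether any other group on this nitrogen would move the number beyond the scatter, such as a phenyl ring carrying an amine or a carboxylic acid, or a cyclohexyl ring in place of the phenyl. From the compounds shown here alone, it also remains open whether the same exchange would read the same way with a shorter or longer chain on the amide.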